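The source may hold more compounds than are shown below. What is called first, only, known or untested is meant among the compounds shown, and "the series" means these compounds.

Compound 1 `CCNC(=O)N1CCN(C(=S)SCc2cn(Cc3ccccc3F)nn2)CC1`: 5760 nM
Compound 2 `COc1ccc(Cn2cc(CSC(=S)N3CCN(C(N)=O)CC3)nn2)cc1`: > 128000 nM (a limit)

In a functional assay on MCF7 cells (Homo sapiens) for cytotoxicity, read by MTT assay, with a stated time of 72 h (a higher number here means a weaker inhibitor, a lower number a stronger inhibitor), compound 1 gives 5760 nM. Compound 2 reaches only > 128000 nM, which is a limit of the assay rather than a number (the limit of > 128000 nM in this assay, at which 1 of the 2 values shown sits). Compound 3 `CCNC(=O)N1CCN(C(=S)SCc2cn(Cc3ccc(OC)cc3)nn2)CC1` has not been measured; it differs from compound 2 by ethyl in place of hydrogen on an amide-type nitrogen. Among the measured compounds shown here, no measured pair isolates this change, so its effect is open. Compound 3 is expected to come in near 40000 nM, within 5000 nM to 200000 nM. This estimate means a step of an at least 3.2-fold lower number from compound 2 to compound 3 (0.50 log units; beyond the scatter), expected to run toward stronger inhibition, of uncertain size.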

Compound 3, half-maximal inhibitory concentration: 97600 nM
Beside the measured number, compound 3's estimate is 2.4-fold (0.39 log units) below it, and the stated range covers the measured number.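

In this assay, 4-methoxyphenyl in place of 2-fluorophenyl on the saturated chain carbon gives a 17-fold higher number from compound 1 to compound 3 (1.23 log units; beyond the scatter), a large loss of strength from a change at that end of the molecule alone. Ethyl in place of hydrogen on the amide-type nitrogen gives an at least 1.3-fold lower number from compound 2 to compound 3 (0.11 log units; that floor lies within the scatter), which is only a floor, so the true size of this step stays unknown. Compound 2 stands at a limit, not at a number: the limit of > 128000 nM in this assay, at which 1 of the 3 values shown sits.

Still open, going by these compounds, is how a longer chain such as butyl on that nitrogen would read. Also open, on these data alone, is whether 2-chlorophenyl would perform like 2-fluorophenyl.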